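The source may report more compounds than this note shows. Statements on the series, on what has been measured and on what is new or still open speak of the compounds shown alone.

Of the compounds shown here, three sharing one core have been measured in a functional assay on MV4-11 cells (Homo sapiens) for inhibition, with a stated time of 120 h, tested at 10 uM; on this read-out lower numbers stand for less inhibition and higher numbers for more inhibition at the one concentration tested (going by the name of the read-out). Compound 1 `Cc1n[nH]c2ccc(-c3nc4cnc(N5CCN(C)CC5)cn4c3Nc3cccc(F)c3)cc12` gives 18.5%. Compound 2 `Cc1n[nH]c2ccc(-c3nc4cnc(N5CCN(C)CC5)cn4c3Nc3ccccc3Cl)cc12` gives 58.1%, and compound 3 `Cc1n[nH]c2ccc(-c3nc4cnc(N5CCN(C)CC5)cn4c3Nc3ccc(I)cc3)cc12` gives 0%. Among these three numbers compound 1 stands second highest: compound 3 lies nearest, with a step of a number 18.5 percentage points lower from compound 1 to compound 3 (beyond the scatter), and compound 2 lies furthest, with a step of a number 39.6 percentage points higher from compound 1 to compound 2 (beyond the scatter).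

Compound 4 `Cc1n[nH]c2ccc(-c3nc4cnc(N5CCN(C)CC5)cn4c3Nc3ccc(Br)cc3Cl)cc12` has not yet been measured in this assay. It differs from compound 1 in one place: 4-bromo-2-chlorophenyl in place of 3-fluorophenyl on a nitrogen on an aromatic ring. Among the measured compounds shown here, two measured steps bear on this change. The step from compound 1 to compound 2 introduces a 2-chlorophenyl in place of the 3-fluorophenyl and raises inhibition by a large amount, a number 39.6 percentage points higher from compound 1 to compound 2 (beyond the scatter). The step from compound 1 to compound 3 introduces a 4-iodophenyl in place of the 3-fluorophenyl and lowers inhibition by a modest amount, a number 18.5 percentage points lower from compound 1 to compound 3 (beyond the scatter). For the measured compounds named here, compound 4 carries both a chlorine and a bromine on the phenyl, so the two steps pull in opposite directions, and no measured pair shows what a bromine does here.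

Weighing the larger rise against the smaller fall, the expected step is a number 16.5 percentage points higher from compound 1 to compound 4 (beyond the scatter). Compound 4 is therefore estimated at 35%, within a range from 5% to 65%.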

Compound 4, a percentage reported as inhibition, at one concentration (the size of the read-out at that concentration, not a potency): 70.5%
Beside the measured number, compound 4's estimate is 35.5 percentage points below it; the measured number lies above the stated range.
By their numbers in this assay, from the lowest: compound 3; then compound 1; then compound 2; then compound 4.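

In this assay, the 4-bromo-2-chlorophenyl group on the nitrogen gives a number 52 percentage points higher from compound 1 to compound 4 (beyond the scatter) and so carries the change well past what the 2-chlorophenyl group reached. Bromo in place of hydrogen on an aromatic carbon of the 2-chlorophenyl group gives a number 12.4 percentage points higher from compound 2 to compound 4 (beyond the scatter) as a modest step, and this pair shows that a bromine added to that ring raises the number rather than lowering it. Replacing the 4-iodophenyl group with the 4-bromo-2-chlorophenyl group gives a number 70.5 percentage points higher from compound 3 to compound 4 (beyond the scatter) as a large step, so the fall seen with the 4-iodophenyl group does not carry over to this halogen pair.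

The compounds shown leave open whether the bromine would raise the number without the chlorine, as a 4-bromophenyl group would show, and whether a 4-methoxy-2-chlorophenyl or 4-amino-2-chlorophenyl group would hold the same level. Nothing in hand gives a reason for any of these steps.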